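The source may hold more compounds than are shown below. What is called first, only, known or untested is meant among the compounds shown, and "the series" means these compounds.

Compound 1, with the structure `O=C(CN(c1nc(Cl)nc2[nH]cnc12)C1CC1)N[C@@H](CO)C(=O)OCc1ccccc1`, was examined in a functional assay on the whole organism (Tail, strain ICR) with Mus musculus as the target, in the tail flick test, with a stated time of 150 min, at a dose of 25 umol/kg by the oral route; on this read-out higher numbers stand for a stronger effect at the one dose given and lower numbers for a weaker effect. In this assay compound 1 gives 27.9%. Going by the values given here, the only other measured compound sharing the same core is compound 2, whose structure is `O=C(OCc1ccccc1)[C@@H]1CCCN1C(=O)CN(c1nc(Cl)nc2[nH]cnc12)C1CC1`; in this assay compound 2 gives 31.1%. The two numbers lie within the usual scatter of each other, so compound 1 stands on level ground with compound 2, and neither result can be set above the other.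

Compound 3, with the structure `NC(=O)CC[C@H](NC(=O)CN(c1nc(Cl)nc2[nH]cnc12)C1CC1)C(=O)OCc1ccccc1`, has not yet been measured in this assay. It differs from compound 1 in one place: carbamoylmethyl in place of hydroxy on a saturated chain carbon, two bonds along the chain from an amide-type nitrogen and a carbonyl carbon. Among the compounds with values here, no step between two measured compounds tests such a change, so there is nothing in the numbers to anchor a direction. Compound 3 is therefore expected to stay near compound 1, with a step from compound 1 to compound 3 that is estimated as a number 2.1 percentage points higher from compound 1 to compound 3 (within the scatter), which is no more than the scatter. For compound 3 the estimate in this assay is 30%, within a range from 15% to 45%.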

Compound 3, a percentage reported as activity, at one dose (the size of the read-out at that dose, not a potency): 31.1%
Beside the measured number, compound 3's estimate is 1.1 percentage points below it; low and high end bracket the measured number.
By their numbers in this assay, from the lowest: compounds 1, 2 and 3 (each within the scatter of the next).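

In this assay, putting carbamoylmethyl in place of hydroxy on a saturated chain carbon, two bonds along the chain from an amide-type nitrogen and a carbonyl carbon, gives a step of a number 3.2 percentage points higher from compound 1 to compound 3 (within the scatter). Going by these compounds alone, this is the first reading of any change at this position, since the earlier compounds offered no step there, and it shows that a group of 4 heavy atoms can replace one of 1 heavy atom without the read-out moving beyond the scatter. The change leaves the counts of hydrogen-bond donors and acceptors as they were, and no measurement available here offers an explanation for the level result.

What the compounds shown leave open is whether another group at this place, such as an amine, a carboxylic acid or a chain longer than 2-carbamoylethyl, would move the read-out beyond the scatter. They also leave open whether the level result holds at other doses and times, as each compound is read at one dose and one time, which gives the size of the effect there and not a potency.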